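One Carbon Less: From Compound 2 to Compound 3

This account rests on a few compounds, and the source may have more. Where it says the series, first, only, none or still open, it means among the compounds named here.

Of the compounds shown here, two have so far been tested in a functional assay on HCT-8 cells (Homo sapiens) for cytotoxicity; a higher number here means a weaker inhibitor, a lower number a stronger inhibitor. Compound 1 `CC/C=C/[C@H](CC)C[C@@]1(C)C[C@@H](CC)[C@@H](CC(=O)OC)OO1` gives 3 ug/mL there. Compound 2 `CC/C=C/[C@H](CC)C[C@]1(CC)C=C(CC)/C(=C/C(=O)OC)O1` gives 7.2 ug/mL in this assay, the higher of the two numbers and thus the weaker inhibitor, a gap to compound 1 that lies beyond the usual scatter. Compound 3 `CC/C=C/[C@H](CC)C[C@]1(C)C=C(CC)/C(=C/C(=O)OC)O1` has not yet been measured. It differs from compound 2 in one place: hydrogen in place of methyl on a saturated chain carbon bound to a saturated ring carbon. Among the measured compounds shown here, no measured pair isolates this change, so the step in this assay is expected to be small, in either direction or none beyond the scatter: a 1.2-fold lower number from compound 2 to compound 3 (0.08 log units; within the scatter). Compound 3 is estimated at 6 ug/mL, with a likely range from 2.5 ug/mL to 15 ug/mL.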

Compound 3, half-maximal inhibitory concentration: > 25 ug/mL
Compound 3 was reported as a limit (the forecaster's own chance of this, stated with the estimate: 5%); at least 4.1-fold (0.61 log units) between middle value and limit.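

In this assay, cutting ethyl to methyl gives an at least 3.4-fold higher number from compound 2 to compound 3 (0.54 log units; beyond the scatter), so this single carbon, on a saturated chain carbon bound to a saturated ring carbon, clearly matters, and compound 3 is the weaker inhibitor of the pair. The result for compound 3 is a limit of the assay, not a number: the limit of > 25 ug/mL in this assay, at which 1 of the 3 values shown sits.

On these data alone, whether a longer chain, such as propyl, would keep or improve on the number of compound 2 remains open. So does what an amine at the end of that chain would do.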